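A few compounds are considered here, and "the series" means these few. Any claim that something is new, unique, unknown or untested is made for them only; others in the source may bear on it.

The three measured compounds share one core and differ only in the aromatic group that sits on a triple-bonded carbon. Compound 1 `C[C@@H](NC(=O)c1ccc(C#Cc2ccccc2F)cn1)C(C)(C)O` carries a 2-fluorophenyl there, and in a functional assay on HEK293 cells for positive allosteric modulation of metabotropic glutamate receptor 5 (Rattus norvegicus), read by fluorescence and calcium flux (on this read-out lower numbers stand for smaller maximal responses and higher numbers for larger maximal responses), compound 1 reaches 60%. Compound 2 `Cc1cccc(C#Cc2ccc(C(=O)N[C@H](C)C(C)(C)O)nc2)c1` carries a 3-methylphenyl, and in this assay compound 2 reaches 68.6%. Compound 3 `C[C@@H](NC(=O)c1ccc(C#Cc2ccncc2)cn1)C(C)(C)O` carries a pyridin-4-yl, and in this assay compound 3 reaches 66.6%. Compound 2 holds the highest of the three numbers, but every gap is small: a number 8.6 percentage points higher from compound 1 to compound 2 (within the scatter), a number 2 percentage points lower from compound 2 to compound 3 (within the scatter), and a number 6.6 percentage points higher from compound 1 to compound 3 (within the scatter), all of them within the scatter.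

Compound 4 `C[C@@H](NC(=O)c1ccc(C#Cc2ncccc2F)cn1)C(C)(C)O` differs from compound 2 in one place: 3-fluoropyridin-2-yl in place of 3-methylphenyl on a triple-bonded carbon. For the measured compounds named here, two measured steps bear on this exchange, the one that brought a 3-methylphenyl in for a 2-fluorophenyl and the one that put a pyridin-4-yl in for a 3-methylphenyl. Going by the values given here, neither moved the maximal response beyond the scatter, and no measured step on this position did. The expected step in this assay is therefore a number 3.6 percentage points lower from compound 2 to compound 4 (within the scatter), no change beyond the scatter in either direction. Compound 4 is estimated to reach 65% in this assay, with a range from 52% to 78%.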

Compound 4, largest response reached (reported as efficacy), in percent of the reference or control that the assay uses: 60.6%
Beside the measured number, compound 4's estimate is 4.4 percentage points above it, and the stated range covers the measured number.
By their numbers in this assay, from the lowest: compounds 1, 4, 3 and 2 (each within the scatter of the next).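

In this assay the 3-fluoropyridin-2-yl group, the only one of the four on this triple-bonded carbon to carry both a ring nitrogen and a fluorine, gives no step beyond the scatter against any of the other three groups: a number 8 percentage points lower from compound 2 to compound 4 (within the scatter) and a number 6 percentage points lower from compound 3 to compound 4 (within the scatter) and a number 0.6 percentage points higher from compound 1 to compound 4 (within the scatter). The exchange for 3-methylphenyl brings in a hydrogen-bond acceptor on a ring with a hetero atom, at the same count of heavy atoms, and the maximal response does not move beyond the scatter, so this position has now taken four different aromatic groups with the numbers still inside the scatter of one another. Nothing shown gives a reason for this flat picture.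

As far as these compounds go, all four groups are six-membered aromatic rings, so it stays open whether a saturated ring such as cyclohexyl, a longer alkyl chain, or a ring bearing an amine or a carboxylic acid would hold the maximal response on this carbon. Also open, from the compounds shown here alone, is whether any of these exchanges would show a difference in a read-out other than the largest response reached.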